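A few compounds are considered here, and "the series" means these few. Any claim that something is new, unique, unknown or untested is made for them only; others in the source may bear on it.

Compound 2 `N#CC1=C(NC(=S)Nc2ccc(Br)cc2)N(c2ccc(S(N)(=O)=O)cc2)C2=C(C(=O)CCC2)C1c1ccc(Cl)cc1Cl` stands highest of the two numbers measured here: in a functional assay on Ehrlich cells (Mus musculus) for cytotoxicity, read by trypan blue exclusion, with a stated time of 2 h, tested at 25 ug/mL (a higher number here means a stronger effect of the compound at the concentration tested, a lower number a weaker effect), compound 2 gives 50%, whereas compound 1 `CCCCNC(=S)NC1=C(C#N)C(c2ccc(Cl)cc2Cl)C2=C(CCCC2=O)N1c1ccc(S(N)(=O)=O)cc1` gives 30%. Compound 3 `N#CC1=C(NC(N)=O)N(c2ccc(S(N)(=O)=O)cc2)C2=C(C(=O)CCC2)C1c1ccc(Cl)cc1Cl` differs from compound 2 by a group of 3 heavy atoms (1 carbon, 1 nitrogen, 1 oxygen; no ring) in place of a group of 10 heavy atoms (7 carbon, 1 nitrogen, 1 sulfur, 1 bromine; one six-membered aromatic ring of carbon only), on an amine nitrogen. Going by the values given here, one measured step bears on this change: a number 20 percentage points higher from compound 1 to compound 2 (beyond the scatter), where the larger ring-bearing group entered. Compound 3 goes the other way, to a much smaller group, so the number is expected to fall, with an estimated step of a number 25 percentage points lower from compound 2 to compound 3 (beyond the scatter). Compound 3 is therefore expected to give about 25%, in a range from 10% to 45%.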

Compound 3, a percentage reported as activity, at one concentration (the size of the read-out at that concentration, not a potency): 35%
For compound 3 the middle estimate is 10 percentage points below the measured one; low and high end bracket the measured number.
By their numbers in this assay, from the lowest: compounds 1 and 3 (each within the scatter of the next); then compound 2.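

In this assay, carbamoyl in place of the larger ring-bearing group on the amine nitrogen gives a number 15 percentage points lower from compound 2 to compound 3 (beyond the scatter) and so leaves compound 2 on top. Carbamoyl in place of the butyl-bearing group gives a number 5 percentage points higher from compound 1 to compound 3 (within the scatter) so these two ring-free groups are not told apart, despite their different sizes. Nothing measured here explains why these numbers differ.

Whether the ring or its bromine accounts for the higher number of compound 2 stays open. A plain phenyl ring in that group would address this, and a longer chain would test the ring-free side.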